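The compounds below may be only part of what the source reports. "The series", "measured", "known", "first", "only" and "open" are said of these compounds alone.

Of the compounds shown here, three share one core and have been tested in a functional assay on MCF7 cells (Homo sapiens) for cytotoxicity, read by sulforhodamine B assay, with a stated time of 48 h; on this read-out lower numbers stand for stronger inhibition of growth and higher numbers for weaker inhibition of growth. Compound 3 `COc1ccc(/C(Cl)=C/C=C(\C#N)C(=O)c2c[nH]c3ccccc23)cc1` gives 47300 nM, the highest number of the three. Compound 2 `COc1ccc2[nH]cc(C(=O)/C(C#N)=C/C=C(\Cl)c3ccc(OC)c(OC)c3)c2c1` gives 44900 nM, which sits within the usual scatter of compound 3. Compound 1 `COc1cc(/C(Cl)=C/C=C(\C#N)C(=O)c2c[nH]c3ccccc23)cc(OC)c1OC`, which carries further methoxy groups on the same ring, gives 4000 nM, a clearly lower number than compound 3. Compound 4 `COc1ccc(/C(Cl)=C/C=C(\C#N)C(=O)c2c[nH]c3ccccc23)cc1OC` differs from compound 3 by a single change: methoxy in place of hydrogen on an aromatic carbon. Among the compounds with values here, no directly comparable step has been measured, but compound 1 with 4000 nM suggests added methoxy groups can lower the number. A modest drop in this assay is therefore expected from compound 3 to compound 4, of about a 3.2-fold lower number from compound 3 to compound 4 (0.50 log units; beyond the scatter). For compound 4 the expected value is 15000 nM, with a likely range from 5000 nM to 45000 nM.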

Compound 4, concentration for 50% growth inhibition: 44200 nM
Beside the measured number, compound 4's estimate is 2.9-fold (0.47 log units) below it; the measured number falls inside the stated range.
By their numbers in this assay, from the lowest: compound 1; then compounds 4, 2 and 3 (each within the scatter of the next).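

In this assay, placing a methoxy group on this ring, ortho to a methoxy group, gives a 1.1-fold lower number from compound 3 to compound 4 (0.03 log units; within the scatter), so this single change has no visible effect here. Removing a methoxy group from another place gives a similar result, a 1.0-fold lower number from compound 2 to compound 4 (0.01 log units; within the scatter). Within the data shown here, the one large step is an 11-fold higher number from compound 1 to compound 4 (1.04 log units; beyond the scatter), so on this ring a clearly lower number is seen only in the compound with the further methoxy group.

Nothing available explains this difference. On these data alone, whether an amine or a hydroxyl group at this position would change the number remains open.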